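From morpholin-4-yl to amino on a carbonyl carbon

The compounds below may be only part of what the source reports. "The series", "measured", "known", "first", "only" and "open" are said of these compounds alone.

In a functional assay on HT-29 cells (Homo sapiens) (on this read-out higher numbers stand for an effect only at larger amounts of compound and lower numbers for an effect already at smaller amounts), compound 1 (`NC(=O)Nc1sc(-c2ccc(C(=O)N3CCOCC3)cc2)cc1C(=O)N[C@H]1CCCNC1`) gives 610 nM as the lower of the two numbers available. Compound 2 (`CC(=O)Nc1cccc(-c2cc(C(=O)N[C@H]3CCCNC3)c(NC(N)=O)s2)c1`) gives 1800 nM and thus stands higher, with a gap beyond the usual scatter. Compound 3 (`CNC(=O)c1cc(-c2ccccc2)sc1NC(N)=O`) adds no comparison: its entry reads "not determined" (no result reported) and carries no number.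

The next compound to be measured is compound 4 (`NC(=O)Nc1sc(-c2ccc(C(N)=O)cc2)cc1C(=O)N[C@H]1CCCNC1`). The change from the structure of compound 1 is amino in place of morpholin-4-yl on a carbonyl carbon; amino takes the place of morpholin-4-yl on a carbonyl carbon, so that (morpholin-4-yl)carbonyl becomes carbamoyl. Among the compounds with values here, no measured pair isolates this change, so any forecast remains weakly grounded.

The estimated step of a 1.5-fold higher number from compound 1 to compound 4 (0.17 log units; within the scatter) in this assay is expected to lean towards a higher number without clearly leaving the scatter. With only compound 2 at 1800 nM for comparison, the range is kept wide. For compound 4 the expected value is 900 nM with an estimated range of 300 nM to 2700 nM around it.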

Compound 4, half-maximal effective concentration: 3200 nM
For compound 4 the middle estimate is 3.6-fold (0.55 log units) below the measured one; measured number outside the range, above it.
By their numbers in this assay, from the lowest: compound 1; then compounds 2 and 4 (each within the scatter of the next).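

In this assay, within the data shown here, amino in place of morpholin-4-yl on a carbonyl carbon gives a 5.2-fold higher number from compound 1 to compound 4 (0.72 log units; beyond the scatter) as the first step that isolates a single change. This position is therefore not indifferent to what stands on the carbonyl carbon: cutting (morpholin-4-yl)carbonyl back to carbamoyl means that an effect appears only at larger amounts of compound. Nothing measured here accounts for the size of this step.

As far as these compounds go, it remains open whether the step follows from the loss of the ring or from the change to an unsubstituted amide, and dimethylamino or piperidin-1-yl on the same carbonyl carbon would help separate the two. From the compounds shown here alone, with a single pair, it also remains open whether the same change would act alike in compounds that differ elsewhere.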